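Tert-butyl for Methoxycarbonyl on a Shared Urea Core

The source may hold more compounds than are shown below. What is called first, only, known or untested is meant among the compounds shown, and "the series" means these compounds.

Compound 1, `COc1ccc(NC(=O)Nc2cc(C)nc3ccccc23)cc1F`, gives 2700 nM.
Compound 2, `COC(=O)c1ccc(NC(=O)Nc2cc(C)nc3ccccc23)cc1`, gives 1200 nM.
Compound 3, `Cc1cc(NC(=O)Nc2ccc(Cl)c(Cl)c2)c2ccccc2n1`, gives 300 nM.

The three measured compounds share a urea core and differ only in the group on the second aryl ring. In a physicochemical assay for solubility, at pH 7.4 (on this read-out higher numbers stand for higher solubility and lower numbers for lower solubility), compound 2 stands second highest of the three numbers: compound 1 lies above it by a margin beyond the usual scatter, and compound 3 lies below it by a wider margin, also beyond the scatter.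

Compound 4, `Cc1cc(NC(=O)Nc2ccc(C(C)(C)C)cc2)c2ccccc2n1`, has not yet been measured. It differs from compound 2 in one place: tert-butyl in place of methoxycarbonyl on an aromatic carbon. Within the data shown here, no measured pair shows exactly this exchange, so the size of the step is open. Among the measured compounds shown here, the only guide is that compound 3, which carries no oxygen-bearing group on that ring, shows the lowest number of the set. On that basis the step from compound 2 to compound 4 is expected to go downward, by a 3.0-fold lower number from compound 2 to compound 4 (0.48 log units; beyond the scatter), beyond the scatter. Compound 4 is therefore estimated at 400 nM, with a plausible range from 150 nM to 1100 nM.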

Compound 4, solubility: 6200 nM
For compound 4 the middle estimate is 16-fold (1.19 log units) below the measured one, and the stated range ends below it.
By their numbers in this assay, from the lowest: compound 3; then compound 2; then compound 1; then compound 4.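

In this assay, among these compounds, the exchange of methoxycarbonyl for tert-butyl gives a 5.2-fold higher number from compound 2 to compound 4 (0.71 log units; beyond the scatter), the only step here between compounds that differ in one place. It shows that, on this aromatic carbon para to a large group, an all-carbon group with 0 hydrogen-bond acceptors can replace a group of the same heavy-atom count with 2 hydrogen-bond acceptors, and the number goes up. Nothing shown accounts for the size or direction of this step.

The compounds shown leave open whether the rise is particular to tert-butyl or would also appear with isopropyl or a longer chain at this place. They also leave open what an amine or a carboxylic acid would give there, and whether the same exchange would give a similar step on another core.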